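Swapping a Pyridyl Ketone Link for a Carbamate Link

The compounds below may be only part of what the source reports. "The series", "measured", "known", "first", "only" and "open" are said of these compounds alone.

Compound 1 `COc1nc(C)c(Nc2nc(Cl)cn([C@H](COC(=O)c3ccccn3)C3CC3)c2=O)cc1C` carries a pyridin-2-yl group on a carbonyl carbon. In an assay on frontal cortex for displacement of a labelled ligand from corticotropin-releasing factor receptor 1 (Rattus norvegicus), with a stated time of 2 h (on this read-out lower numbers stand for stronger inhibition and higher numbers for weaker inhibition), compound 1 gives 67 nM, the highest number among the three measured compounds, so it is the weakest inhibitor of this small set. Compound 2 `COc1nc(C)c(Nc2nc(Cl)cn([C@H](COC(=O)Nc3ccccc3)C3CC3)c2=O)cc1C` gives 1.5 nM and compound 3 `COc1nc(C)c(Nc2nc(Cl)cn([C@H](COC(=O)Nc3ccc(Cl)cc3)C3CC3)c2=O)cc1C` gives 1.6 nM. Both steps away from compound 1 are large: a 45-fold lower number from compound 1 to compound 2 (1.65 log units; beyond the scatter) and a 42-fold lower number from compound 1 to compound 3 (1.62 log units; beyond the scatter). Between compound 2 and compound 3 the numbers hardly differ, since a 1.1-fold higher number from compound 2 to compound 3 (0.03 log units; within the scatter).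

Compound 4 `COc1nc(C)c(Nc2nc(Cl)cn([C@H](COC(=O)Nc3cccnc3)C3CC3)c2=O)cc1C` differs from compound 1 in one place: (pyridin-3-yl)amino in place of pyridin-2-yl on a carbonyl carbon. As with the anilino and (4-chlorophenyl)amino groups of compound 2 and compound 3, a nitrogen-linked ring replaces the pyridin-2-yl on the carbonyl carbon, and both of those steps lowered the number well beyond the scatter. A step of similar direction and size is therefore expected, a 22-fold lower number from compound 1 to compound 4 (1.35 log units; beyond the scatter). Compound 4 is estimated at 3 nM, with a likely range from 1 nM to 12 nM.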

Compound 4, half-maximal inhibitory concentration: 10 nM
Compound 4: middle estimate off by 3.3-fold (0.52 log units), on the low side; measured number inside the range.
By their numbers in this assay, from the lowest: compounds 2 and 3 (each within the scatter of the next); then compound 4; then compound 1.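

The carbamate link keeps part of its gain when the ring carries a nitrogen: compound 4 still improves on the pyridin-2-yl group of compound 1 (a 6.7-fold lower number from compound 1 to compound 4 (0.83 log units; beyond the scatter)). The ring on the amide-type nitrogen is nevertheless not a free choice, since pyridin-3-yl gives up part of what phenyl and 4-chlorophenyl reach (a 6.7-fold higher number from compound 2 to compound 4 (0.82 log units; beyond the scatter) and a 6.3-fold higher number from compound 3 to compound 4 (0.80 log units; beyond the scatter)), whereas adding the chloro to the phenyl changed nothing beyond the scatter. The data at hand offer no explanation for these differences.

The step from compound 1 to compound 4 changes the link and the place of the ring nitrogen together, so their shares remain unseparated. A (pyridin-2-yl)amino group on the same carbonyl carbon would separate them, and a plain phenyl on that carbon would test the link from the other side.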